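1,3-Thiazol-2-yl in place of pyridin-2-yl: a small expected step

The compounds below may be only part of what the source reports. "The series", "measured", "known", "first", "only" and "open" are said of these compounds alone.

Measured so far in a functional assay on MCF7 cells (Homo sapiens) for inhibition, read by MTT assay, with a stated time of 72 h; a higher number here means a weaker inhibitor, a lower number a stronger inhibitor
compound 1 (`O=C(Nc1ccc(F)c(Br)c1)C1CCN(C/C=C/c2ccccc2)CC1`) gives 13500 nM
compound 2 (`N#Cc1ccc(NC(=O)C2CCN(C/C=C/c3ccccc3)CC2)cc1`) gives 44500 nM
compound 3 (`O=C(Nc1ccccn1)C1CCN(C/C=C/c2ccccc2)CC1`) gives 67200 nM

Compound 3 sits together with compound 2 at the high-number end of this assay (a 1.5-fold higher number from compound 2 to compound 3 (0.18 log units; within the scatter)). Only compound 1 lies clearly apart (a 5.0-fold higher number from compound 1 to compound 3 (0.70 log units; beyond the scatter)).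

Compound 4 (`O=C(Nc1nccs1)C1CCN(C/C=C/c2ccccc2)CC1`) has not been measured yet. It keeps the core of compound 3 and carries 1,3-thiazol-2-yl in place of pyridin-2-yl on an amide-type nitrogen.

The two steps into compound 3 changed the group at this same place, so they are the best guide: one stayed within the scatter and the other was modest. The remaining step at this place was also modest (a 3.3-fold higher number from compound 1 to compound 2 (0.52 log units; beyond the scatter)). Going by these compounds, none of them tests a five-membered ring, so the direction stays open, and no step beyond the scatter is expected in this assay. The expected step is small (a 1.2-fold lower number from compound 3 to compound 4 (0.09 log units; within the scatter)). Compound 4 is estimated at 55000 nM (expected range 22000 nM to 120000 nM).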

Compound 4, half-maximal inhibitory concentration: 28600 nM
For compound 4 the middle estimate is 1.9-fold (0.28 log units) above the measured one; measured number inside the range.
By their numbers in this assay, from the lowest: compound 1; then compounds 4, 2 and 3 (each within the scatter of the next, the first and the last beyond it).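

In this assay, the only five-membered ring among these compounds at this amide-type nitrogen gives a measurable change: 1,3-thiazol-2-yl in place of pyridin-2-yl produces a 2.3-fold lower number from compound 3 to compound 4 (0.37 log units; beyond the scatter), so a ring swap of this kind is not silent here. Compound 4 still lies within the scatter of compound 2 (a 1.6-fold lower number from compound 2 to compound 4 (0.19 log units; within the scatter)), while compound 1 remains the strongest inhibitor of the four (a 2.1-fold higher number from compound 1 to compound 4 (0.33 log units; beyond the scatter)), so the new ring does not match the 3-bromo-4-fluorophenyl group. Nothing measured here accounts for the change.

The compounds shown cannot separate the contribution of the sulfur atom from that of the smaller ring. Going by these compounds, what an oxazol-2-yl ring, or a 1,3-thiazol-2-yl ring carrying a methyl group or a bromine, would give at this nitrogen remains open.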